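The compounds below may be only part of what the source reports. "The series", "measured", "known", "first", "only" and "open" are said of these compounds alone.

Compound 1 `CCOC(=O)c1c(-c2cccc(Oc3ccccc3)c2)[nH]c2cc(OC)c(F)cc2c1=O`: 560 10^-6 cm/s
Compound 2 `CCOC(=O)c1c(-c2cccc(Cl)c2)[nH]c2cc(OC)c(F)cc2c1=O`: 410 10^-6 cm/s
Compound 3 `CCOC(=O)c1c(-c2cccc(Br)c2)[nH]c2cc(OC)c(F)cc2c1=O`: 670 10^-6 cm/s

These values come from an ADME assay for permeability, using PAMPA, at pH 7.4; a higher number here means that the compound crosses the layer faster, a lower number that the compound crosses the layer more slowly. Compound 3 is not separated from the other two compounds, with steps of a 1.2-fold higher number from compound 1 to compound 3 (0.08 log units; within the scatter) and a 1.6-fold higher number from compound 2 to compound 3 (0.21 log units; within the scatter). Compound 4 `CCOC(=O)c1c(-c2cc(F)cc(OC)c2)[nH]c2cc(OC)c(F)cc2c1=O` carries 3-fluoro-5-methoxyphenyl in place of 3-bromophenyl on an aromatic carbon. The three measured steps, which also include a 1.4-fold lower number from compound 1 to compound 2 (0.14 log units; within the scatter), all exchange a single group on the phenyl ring, and none goes beyond the scatter. None of them tests fluoro and methoxy together, so they bear on this change only indirectly. No shift beyond the scatter is therefore expected, and the estimated step is a 1.3-fold lower number from compound 3 to compound 4 (0.13 log units; within the scatter). For compound 4 the expected value is 500 10^-6 cm/s, within an estimated range from 250 10^-6 cm/s to 900 10^-6 cm/s.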

Compound 4, apparent permeability in the ADME assay: 230 10^-6 cm/s
For compound 4 the middle estimate is 2.2-fold (0.34 log units) above the measured one; measured number below the stated range.
By their numbers in the ADME assay, from the lowest: compounds 4, 2, 1 and 3 (each within the scatter of the next, the first and the last beyond it).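

In the ADME assay compound 3 (670 10^-6 cm/s) and compound 4 (230 10^-6 cm/s) now show a step beyond the scatter (a 2.9-fold lower number from compound 3 to compound 4 (0.46 log units; beyond the scatter)), which no exchange among compound 1, compound 2 and compound 3 had done, while the step from the 3-chlorophenyl group of compound 2 (410 10^-6 cm/s) stays within it (a 1.8-fold lower number from compound 2 to compound 4 (0.25 log units; within the scatter)). In a physicochemical assay for solubility, at pH 7.4 (a lower number here means a less soluble compound, a higher number a more soluble compound), compound 3 (7300 nM) and compound 4 (7500 nM) are not separated by the same change (a 1.0-fold higher number from compound 3 to compound 4 (0.01 log units; within the scatter)), so the two read-outs part ways here. Nothing at hand explains the step. The compounds shown leave open whether fluoro or methoxy alone accounts for it, and how an amine or a carboxylic acid on this phenyl ring would read in the ADME assay.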